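Two Anilines at the Limit, a Third to Measure

The source may report more compounds than this note shows. Statements on the series, on what has been measured and on what is new or still open speak of the compounds shown alone.

Compounds measured so far:
compound 1, `COc1ccccc1Nc1nc(-c2cccc(F)c2)nc2ccc(F)cc12`
compound 2, `Fc1ccc(Nc2nc(-c3cccc(F)c3)nc3ccc(F)cc23)cc1`
Not yet measured:
compound 3, `Cc1cccc(Nc2nc(-c3cccc(F)c3)nc3ccc(F)cc23)c1`

In a functional assay on U2OS cells (Homo sapiens) for cytotoxicity, read by MTT assay, with a stated time of 48 h (a lower number here means a stronger inhibitor, a higher number a weaker inhibitor), compound 1 gives only a limit, > 50000 nM. Compound 2 in this assay likewise gives only a limit, > 50000 nM. The step from compound 1 to compound 2, 4-fluorophenyl in place of 2-methoxyphenyl on a nitrogen on an aromatic ring, is a step that the two limits leave unreadable from compound 1 to compound 2. Compound 2 thus stands where the numbers stop: both values shown sit at the limit of > 50000 nM in this assay, at which 2 of the 2 values shown sit, and its own value is one of them.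

Compound 3 differs from compound 2 by 3-methylphenyl in place of 4-fluorophenyl on a nitrogen on an aromatic ring. Among the measured compounds shown here, the only measured step touches the same position, yet its size cannot be read, so it gives no direction for this one. Because both values shown sit at the limit of > 50000 nM in this assay, at which 2 of the 2 values shown sit, the expectation for compound 3 is that it too remains at or near the limit. Compound 3 is therefore estimated at 60000 nM, with a range from 20000 nM to 200000 nM. The step this estimate means, a step that the limit leaves unreadable from compound 2 to compound 3, is expected to stay within the scatter.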

Compound 3, half-maximal inhibitory concentration: > 50000 nM
Compound 3: only a limit was reported (the forecaster's own chance of this, stated with the estimate: 75%); the middle value is on the limit's open side.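

In this assay compound 3 gives > 50000 nM as a limit only. Among the compounds shown here, with compound 1, compound 2 and compound 3 all reported as limits, no step among them can be read. The compounds shown leave open whether the group on that nitrogen changes the cytotoxicity at all, as all three stand at one place: the limit of > 50000 nM in this assay, at which 3 of the 3 values shown sit.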